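The source may report more compounds than this note shows. Statements on the series, on what has been measured and on what is new or still open speak of the compounds shown alone.

Measured compounds in the series:

compound 1, `[N-]=[N+]=N[C@@H]1C(n2cc(F)c(=O)[nH]c2=O)[Se][C@H](CO)[C@H]1O` — > 100000 nM
compound 2, `[N-]=[N+]=N[C@@H]1C(n2cc(Br)c(=O)[nH]c2=O)[Se][C@H](CO)[C@H]1O` — > 100000 nM
compound 3, `[N-]=[N+]=N[C@@H]1C(n2cc(I)c(=O)[nH]c2=O)[Se][C@H](CO)[C@H]1O` — not yet measured

In a functional assay on T47D cells (Homo sapiens) for cytotoxicity, read by sulforhodamine B assay (on this read-out higher numbers stand for weaker inhibition and lower numbers for stronger inhibition), compound 1 gives > 100000 nM, which is a limit of the assay and not a number. In this assay compound 2 gives > 100000 nM, again a limit of the assay and not a number. For the measured compounds named here, the one measured change, a step that the two limits leave unreadable from compound 1 to compound 2, is therefore of unknown size and direction. Compound 2 stands at the limit of > 100000 nM in this assay, at which 2 of the 2 values shown sit, with no value of the series measured as a number.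

Compound 3 differs from compound 2 by iodo in place of bromo on an aromatic carbon. Going by the values given here, the only step that bears on this change is a step that the two limits leave unreadable from compound 1 to compound 2, and it is unreadable. Within this series halogen exchange on the aromatic carbon has so far produced no measurable value. Compound 3 is therefore expected to be reported at the same limit, with an estimate of 150000 nM and a range of 50000 nM to 500000 nM. The expected step is a step that the limit leaves unreadable from compound 2 to compound 3, not a change beyond the scatter.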

Compound 3, half-maximal inhibitory concentration: > 100000 nM
Compound 3: only a limit was reported; the forecaster's own chance of this, stated with the estimate: 85%; the middle value is on the limit's open side.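

No step can be read among compound 1, compound 2 and compound 3 in this assay, as all three values are limits of the assay and not numbers: the limit of > 100000 nM in this assay, at which 3 of the 3 values shown sit.

The compounds shown leave open whether exchanging fluoro, bromo and iodo on the aromatic carbon changes the read-out at all, and in which direction.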